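Heteroaryl swap on sulfur, compound 3 to compound 4

The source may report more compounds than this note shows. Statements on the series, on what has been measured and on what is new or still open speak of the compounds shown alone.

Measured so far in a functional assay (trachea) with Cavia porcellus as the target; on this read-out lower numbers stand for stronger inhibition and higher numbers for weaker inhibition:
- compound 1 `CC(=O)Cn1nc(-c2cccnc2)c2ccccc2c1=O`: 40700 nM
- compound 2 `CCOC(=O)Cn1nc(-c2cccnc2)c2ccccc2c1=O`: 43700 nM
- compound 3 `O=c1c2ccccc2c(-c2cccnc2)nn1CCSc1nccs1`: 10500 nM

Compound 3 holds the lowest of the three numbers, and its steps to both other compounds lie beyond the scatter. Compound 4 `O=c1c2ccccc2c(-c2cccnc2)nn1CCSc1ncccn1` differs from it only in the group on the sulfur, with pyrimidin-2-yl in place of 1,3-thiazol-2-yl on a sulfur.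

Among the measured compounds shown here, no measured step makes this exchange, so the evidence is indirect. Replacing the whole side-chain end gave modest steps: a 3.9-fold lower number from compound 1 to compound 3 (0.59 log units; beyond the scatter) and a 4.2-fold lower number from compound 2 to compound 3 (0.62 log units; beyond the scatter). The change from acetyl to the ethoxy-bearing carbonyl gave a 1.1-fold higher number from compound 1 to compound 2 (0.03 log units; within the scatter), which lies within the scatter. The saturated chain and the sulfur of compound 3 stay in place here, so a step smaller than those two modest ones is expected in this assay, with no clear direction. The expected step is a 1.1-fold higher number from compound 3 to compound 4 (0.06 log units; within the scatter), which would not stand out from the scatter. For compound 4 the estimated value is 12000 nM, with an expected range of 4000 nM to 32000 nM.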

Compound 4, half-maximal inhibitory concentration: 11000 nM
The estimate for compound 4 lay 1.1-fold (0.04 log units) above the measured number, and the stated range covers the measured number.
By their numbers in this assay, from the lowest: compounds 3 and 4 (each within the scatter of the next); then compounds 1 and 2 (each within the scatter of the next).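

In this assay, pyrimidin-2-yl in place of 1,3-thiazol-2-yl on a sulfur gives a 1.0-fold higher number from compound 3 to compound 4 (0.02 log units; within the scatter), so the two heteroaryl groups cannot be told apart at this position, although one is a five-membered and the other a six-membered aromatic ring. The advantage over the carbonyl-bearing side chains also holds with the new ring, at a 4.0-fold lower number from compound 2 to compound 4 (0.60 log units; beyond the scatter) and a 3.7-fold lower number from compound 1 to compound 4 (0.57 log units; beyond the scatter), so among these compounds the lower numbers are not confined to the 1,3-thiazol-2-yl group. No measurement of any property of these groups accompanies this result.

From the compounds shown here alone, both compounds with the lower numbers carry an aromatic ring with 2 hetero atoms on a sulfur, so it remains open whether those ring nitrogens or the sulfur itself matter for the read-out. A plain phenyl group on the sulfur, an oxygen in place of the sulfur, a longer chain before the sulfur, or an amine at the chain end would each test a different part of this side chain.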